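The compounds below may be only part of what the source reports. "The series", "measured", "known", "first", "only" and "open" are said of these compounds alone.

Values measured so far in a physicochemical assay for solubility, with a stated time of 18 h, at pH 7.4 (a lower number here means a less soluble compound, a higher number a more soluble compound), are:

Compound 1 `COc1ccc(F)cc1CNCCCNc1ccnc2cc(C3CCCCC3)ccc12` gives 4200 nM
Compound 2 `COc1ccc(F)cc1CNCCCNc1ccnc2cc(Cc3ccccc3)ccc12` gives 4200 nM
Compound 3 `COc1ccc(-c2ccc3c(NCCCNCc4cc(F)ccc4OC)ccnc3c2)cc1` gives 32000 nM

Compound 3 stands highest of the three, and the other two compounds share one value below it. Compound 4 `COc1ccc(F)cc1CNCCCNc1ccnc2cc(Oc3ccccc3)ccc12` has not yet been measured. It carries phenoxy in place of 4-methoxyphenyl on an aromatic carbon, and phenoxy in place of 4-methoxyphenyl on an aromatic carbon gives the counted difference.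

For the measured compounds named here, three measured steps bear on this exchange. Benzyl in place of cyclohexyl gave no change at the digits printed from compound 1 to compound 2 (within the scatter) in this series. Placing 4-methoxyphenyl on the same carbon gave a 7.6-fold higher number from compound 1 to compound 3 (0.88 log units; beyond the scatter) and also a 7.6-fold higher number from compound 2 to compound 3 (0.88 log units; beyond the scatter) as modest rises. Going by the values given here, no phenoxy compound has been measured, so the nearest guide is the benzyl of compound 2 at 4200 nM in this assay as the closest measured group. A modest step to a lower number is therefore expected, reversing most of the rise, though three compounds make a thin basis.

The expected step is a 4.6-fold lower number from compound 3 to compound 4 (0.66 log units; beyond the scatter) in size. For compound 4 the estimate is 7000 nM with an expected range from 2500 nM to 20000 nM in this measurement.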

Compound 4, solubility: 14500 nM
Beside the measured number, compound 4's estimate is 2.1-fold (0.32 log units) below it; low and high end bracket the measured number.
By their numbers in this assay, from the lowest: compounds 1 and 2 (each within the scatter of the next); then compound 4; then compound 3.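

In this assay, phenoxy on this aromatic carbon gives a third level, not a return to one of the two levels seen before: the exchange for 4-methoxyphenyl gives a 2.2-fold lower number from compound 3 to compound 4 (0.34 log units; beyond the scatter) as its result, while the exchange for benzyl gives a 3.5-fold higher number from compound 2 to compound 4 (0.54 log units; beyond the scatter) and the exchange for cyclohexyl gives a 3.5-fold higher number from compound 1 to compound 4 (0.54 log units; beyond the scatter) on the same scale. For the compounds shown here, the earlier compounds showed only one value shared by two groups and one higher value, so they could not show that a group at this position may fall in the interval between them. Phenoxy and 4-methoxyphenyl also match in aromatic ring, hydrogen-bond donors, hydrogen-bond acceptors and net charge, yet their step lies beyond the scatter, so those counts alone do not fix the number, and no measurement shown here accounts for the differences.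

Going by these compounds, what remains open is whether the methoxy group or the oxygen link carries the difference between these two groups, which 4-methoxyphenoxy or 3-methoxyphenyl on the same carbon would help to separate. On these data alone, it is also open how this position would respond to a group of another kind, such as a morpholine, an amine or a carboxylic acid, or to a longer chain ending in a phenyl ring.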